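Piperidine to piperazine on the propoxy chain

The source may hold more compounds than are shown below. What is called first, only, known or untested is meant among the compounds shown, and "the series" means these compounds.

Compound 1 `COc1cc2c(Oc3ccc(NC(=O)c4nn(-c5ccccc5C)c(=O)cc4C)cc3F)ccnc2cc1OCCCN1CCN(C)CC1`: 3720 nM
Compound 2 `COc1cc2c(Oc3ccc(NC(=O)c4nn(-c5ccccc5C(F)(F)F)c(=O)cc4C)cc3F)ccnc2cc1OCCCN1CCN(C)CC1`: 1170 nM
Compound 3 `COc1cc2c(Oc3ccc(NC(=O)c4nn(-c5ccc(Cl)cc5)c(=O)cc4C)cc3F)ccnc2cc1OCCCN1CCC(C)CC1`: 1350 nM

In a functional assay on U-87MG ATCC cells (Homo sapiens) for inhibition, read by MTT assay, with a stated time of 72 h (a higher number here means a weaker inhibitor, a lower number a stronger inhibitor), compound 3 gives 1350 nM, a number that sits alongside that of compound 2 and well below that of compound 1. Compound 4 `COc1cc2c(Oc3ccc(NC(=O)c4nn(-c5ccc(Cl)cc5)c(=O)cc4C)cc3F)ccnc2cc1OCCCN1CCN(C)CC1` differs from compound 3 by 4-methylpiperazin-1-yl in place of 4-methylpiperidin-1-yl on a saturated chain carbon, three bonds along the chain from an oxygen on an aromatic ring. Among the measured compounds shown here, the only measured step, a 3.2-fold lower number from compound 1 to compound 2 (0.50 log units; beyond the scatter), concerns the aryl substituent and not the chain terminus, so no measured step bears on this change; compounds 1 and 2 merely show that the piperazine terminus is compatible with numbers spanning the set. A step of a 1.0-fold lower number from compound 3 to compound 4 (0.02 log units; within the scatter) is therefore expected, none beyond the scatter. Compound 4 is estimated at 1300 nM in this assay, within 450 nM to 3800 nM.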

Compound 4, half-maximal inhibitory concentration: 1560 nM
Compound 4: the middle estimate sits 1.2-fold (0.08 log units) below what was measured, and the stated range covers the measured number.
By their numbers in this assay, from the lowest: compounds 2, 3 and 4 (each within the scatter of the next); then compound 1.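

In this assay, the exchange at the end of the chain gives a 1.2-fold higher number from compound 3 to compound 4 (0.06 log units; within the scatter) and so lies within the scatter, which means 4-methylpiperazin-1-yl and 4-methylpiperidin-1-yl cannot be told apart here with 4-chlorophenyl on the aromatic nitrogen. With the piperazine terminus held, 4-chlorophenyl in place of 2-(trifluoromethyl)phenyl gives a 1.3-fold higher number from compound 2 to compound 4 (0.12 log units; within the scatter) within the scatter, while in place of 2-methylphenyl it gives a 2.4-fold lower number from compound 1 to compound 4 (0.38 log units; beyond the scatter) as a modest step. No evidence at hand accounts for these results. As far as these compounds go, whether the terminus exchange reads the same with the other two aryl groups remains open, as does how a morpholine would read in place of 4-methylpiperazin-1-yl.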